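The source may hold more compounds than are shown below. What is called first, only, known or untested is meant among the compounds shown, and "the series" means these compounds.

Measured so far in a functional assay on T47D cells (Homo sapiens) for inhibition, read by sulforhodamine B assay, with a stated time of 48 h, tested at 10 uM; a lower number here means less inhibition, a higher number more inhibition at the concentration tested (going by the name of the read-out):
compound 1 `COc1ccc(-c2cn3ccnc3c(-c3ccc4ncn(C5CCCCC5)c4c3)n2)cc1` gives -8.6%
compound 2 `O=Cc1ccc(-c2cn3ccnc3c(-c3ccc4ncn(C5CCCCC5)c4c3)n2)cc1` gives 98%
compound 3 `c1ccc2c(-c3cn4ccnc4c(-c4ccc5ncn(C6CCCCC6)c5c4)n3)cccc2c1` gives 41.3%

Compound 3 stands second highest of the three numbers, with compound 1 nearest below it and compound 2 furthest above it. The step from compound 3 to compound 4 `COc1ccccc1-c1cn2ccnc2c(-c2ccc3ncn(C4CCCCC4)c3c2)n1` is 2-methoxyphenyl in place of naphthalen-1-yl on an aromatic carbon. For the measured compounds named here, two measured steps bear on this change: a number 49.9 percentage points higher from compound 1 to compound 3 (beyond the scatter) and a number 56.7 percentage points lower from compound 2 to compound 3 (beyond the scatter). The first is the closer guide, since it swapped a methoxyphenyl group for naphthalen-1-yl, and compound 4 brings a methoxyphenyl group back, though as 2-methoxyphenyl rather than 4-methoxyphenyl, so the two changes are not identical. Only compound 1 carries a methoxy group, so the weight of where the methoxy sits cannot be read from these three compounds. A fall beyond the scatter is nevertheless expected, and the estimated step is a number 33.3 percentage points lower from compound 3 to compound 4 (beyond the scatter). For compound 4 the expected value is 8%, with a range from -15% to 38%.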

Compound 4, a percentage reported as inhibition, at one concentration (the size of the read-out at that concentration, not a potency): 36.6%
The estimate for compound 4 lay 28.6 percentage points below the measured number, within the range that was stated.
By their numbers in this assay, from the lowest: compound 1; then compounds 4 and 3 (each within the scatter of the next); then compound 2.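

In this assay the placing of the methoxy group on the phenyl ring counts, with a number 45.2 percentage points higher from compound 1 to compound 4 (beyond the scatter) when 2-methoxyphenyl stands in place of 4-methoxyphenyl on the same aromatic carbon of the shared core. Naphthalen-1-yl and 2-methoxyphenyl are not separated here, with a number 4.7 percentage points lower from compound 3 to compound 4 (within the scatter) as the step, so a second six-membered aromatic ring of carbon is not required for this level of inhibition. The 4-formylphenyl group keeps its lead, with a number 61.4 percentage points lower from compound 2 to compound 4 (beyond the scatter) as the step, and compound 2 stands beyond the scatter from all three others.

Still open, from the compounds shown here alone, is whether the formyl group itself carries that lead, which a carboxylic acid or a hydroxymethyl group in its place on the phenyl ring would test. Nothing at hand accounts for any of these steps.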